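This account rests on a few compounds, and the source may have more. Where it says the series, first, only, none or still open, it means among the compounds named here.

Working notes on a short ester series built on one shared core. Compound 1 `CCCOC(=O)CCC(=O)N1CCN(CCCOc2cc3c(Nc4ccc(F)c(Cl)c4)ncnc3cc2OC)CC1` carries the shortest ester chain; in a functional assay on A549 cells (Homo sapiens) for cytotoxicity, read by MTT assay, with a stated time of 24 h, tested at 80 uM (on this read-out higher numbers stand for a weaker effect at the one concentration tested and lower numbers for a stronger effect), compound 1 gives 23.4%. Compound 2 `CCCCOC(=O)CCC(=O)N1CCN(CCCOc2cc3c(Nc4ccc(F)c(Cl)c4)ncnc3cc2OC)CC1` differs from compound 1 by methyl in place of hydrogen on a saturated chain carbon, three bonds along the chain from an oxygen next to a carbonyl group, and in this assay compound 2 gives 36.9%. Compound 3 `CCCCCCOC(=O)CCC(=O)N1CCN(CCCOc2cc3c(Nc4ccc(F)c(Cl)c4)ncnc3cc2OC)CC1` differs from compound 1 by propyl in place of hydrogen on a saturated chain carbon, three bonds along the chain from an oxygen next to a carbonyl group, and in this assay compound 3 gives 42.9%.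

The steps run as follows: a number 13.5 percentage points higher from compound 1 to compound 2 (beyond the scatter); a number 19.5 percentage points higher from compound 1 to compound 3 (beyond the scatter); a number 6 percentage points higher from compound 2 to compound 3 (within the scatter). The first lengthening of the chain raises the read-out beyond the scatter, while the further lengthening from compound 2 to compound 3 stays within it.

Compound 4 `CCCCCCCOC(=O)CCC(=O)N1CCN(CCCOc2cc3c(Nc4ccc(F)c(Cl)c4)ncnc3cc2OC)CC1` is not yet measured. It differs from compound 3 by methyl in place of hydrogen on a saturated chain carbon, six bonds along the chain from an oxygen next to a carbonyl group. This is the same kind of change as that made from compound 1 to compound 2, which gave a number 13.5 percentage points higher from compound 1 to compound 2 (beyond the scatter), but the place is not the same: there the methyl entered three bonds along the chain from an oxygen next to a carbonyl group, here six bonds along that chain. The chain is already longer by the difference between the two cores, (propyl in place of hydrogen on a saturated chain carbon, three bonds along the chain from an oxygen next to a carbonyl group).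

In this assay the step from compound 3 to compound 4 is expected to be small, a number 3.1 percentage points higher from compound 3 to compound 4 (within the scatter), smaller than the earlier one. This rests on the step of a number 6 percentage points higher from compound 2 to compound 3 (within the scatter) lying within the scatter, which suggests the rise is flattening. For compound 4 in this assay the estimate is 46%, expected to fall between 36% and 58%.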

Compound 4, a percentage reported as activity, at one concentration (the size of the read-out at that concentration, not a potency): 27.2%
Compound 4: middle estimate off by 18.8 percentage points, on the high side, outside the stated range (below it).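

In this assay, the step of a number 15.7 percentage points lower from compound 3 to compound 4 (beyond the scatter) runs against the direction seen when the chain was first lengthened, so methyl in place of hydrogen does not carry its effect from one core to another in this series: the same change on two cores in this assay, a number 13.5 percentage points higher (beyond the scatter) from compound 1 to compound 2 and a number 15.7 percentage points lower (beyond the scatter) from compound 3 to compound 4, 29.2 percentage points apart, beyond the scatter of two such steps
The step of a number 9.7 percentage points lower from compound 2 to compound 4 (within the scatter) and the step of a number 3.8 percentage points higher from compound 1 to compound 4 (within the scatter) both stay within the scatter, so compound 4 cannot be placed in any order against compound 1 or compound 2, yet the longer change also differs between its two cores: the same change on two cores in this assay, a number 19.5 percentage points higher (beyond the scatter) from compound 1 to compound 3 and a number 9.7 percentage points lower (within the scatter) from compound 2 to compound 4, 29.2 percentage points apart, beyond the scatter of two such steps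
This shows that the result of adding to the ester chain depends on the chain already present, but it does not show why, and with only these compounds it does not establish a general turning point in chain length.

From the compounds shown here alone, whether a longer chain would stay close to compound 4 or move back towards compound 3 remains open. Also open, going by these compounds, is whether a branched chain, or a carboxylic acid in place of the ester, would fit the same uneven pattern in this assay.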